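The source may hold more compounds than are shown below. What is called first, only, known or untested is meant among the compounds shown, and "the series" means these compounds.

Measured so far in an assay for inhibition of acid-sensing ion channel 3 (Homo sapiens), read by patch clamp, tested at 20 uM; a lower number here means less inhibition, a higher number more inhibition at the concentration tested (going by the name of the read-out):
compound 1 `CCCNc1nc(N)c(C(=O)N=C(N)N)nc1Cl`: 91%
compound 2 `CC(C)(C)Nc1nc(N)c(C(=O)N=C(N)N)nc1Cl`: 48%
compound 3 `NC(N)=NC(=O)c1nc(Cl)c(Nc2ccccc2)nc1N`: 95%

Compound 3 has the highest number of the three, but its gap to compound 1 is small, a number 4 percentage points higher from compound 1 to compound 3 (within the scatter), so the two cannot be ranked. Compound 2 sits far lower, a number 47 percentage points higher from compound 2 to compound 3 (beyond the scatter), and also well below compound 1, a number 43 percentage points lower from compound 1 to compound 2 (beyond the scatter).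

Compound 4 `NC(N)=NC(=O)c1nc(Cl)c(Nc2cccc(Cl)c2)nc1N` differs from compound 3 in one place: chloro in place of hydrogen on an aromatic carbon. For the measured compounds named here, every measured step swaps the whole group on the ring nitrogen; none adds a chloro to a phenyl, so no step bears directly on this change. With compound 3 already near the top of the scale, little room remains upward, and the expected step of a number 5 percentage points lower from compound 3 to compound 4 (within the scatter) lies within the scatter. Compound 4 is therefore estimated at 90%, ranging from 70% to 100%.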

Compound 4, a percentage reported as inhibition, at one concentration (the size of the read-out at that concentration, not a potency): 94%
For compound 4 the middle estimate is 4 percentage points below the measured one; low and high end bracket the measured number.
By their numbers in this assay, from the lowest: compound 2; then compounds 1, 4 and 3 (each within the scatter of the next).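

In this assay, adding chloro to the phenyl group of compound 3 gives no readable shift (a number 1 percentage points lower from compound 3 to compound 4 (within the scatter)). The 3-chlorophenyl group keeps the standing that phenyl had against the other two ring-nitrogen groups, with no separation from propyl (a number 3 percentage points higher from compound 1 to compound 4 (within the scatter)) and a large gap over tert-butyl (a number 46 percentage points higher from compound 2 to compound 4 (beyond the scatter)). No evidence on the cause of this result is available.

On these data alone, whether chloro elsewhere on the phenyl ring, or a methoxy or nitrile group at this place, would fit the same picture stays open. Readings this close to the top of the scale at one concentration also leave any difference in potency unresolved.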